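Trifluoromethyl in place of hydrogen: from compound 1 to compound 3

The source may report more compounds than this note shows. Statements on the series, on what has been measured and on what is new or still open speak of the compounds shown alone.

In a functional assay, read by Griess assay, with a stated time of 2.5 h (a lower number here means a stronger inhibitor, a higher number a weaker inhibitor), compound 1 (`COc1cc(OC)c(OC)cc1/C=C/C(=O)c1ccccc1`) gives 2.01 ug/mL and compound 2 (`COc1cc(OC)c(OC)cc1/C=C/C(=O)c1ccc(C)cc1`) gives 2.18 ug/mL and the two lie within the scatter of each other. Compound 3 (`COc1cc(OC)c(OC)cc1/C=C/C(=O)c1cccc(C(F)(F)F)c1`) is not yet measured, and its difference from compound 1 is trifluoromethyl in place of hydrogen on an aromatic carbon with trifluoromethyl in place of hydrogen on an aromatic carbon. Going by the values given here, the only measured step that bears on this is a 1.1-fold higher number from compound 1 to compound 2 (0.04 log units; within the scatter) for methyl in place of hydrogen on an aromatic carbon. That single step involves a different group and gives thin support, but no change beyond the scatter is expected. The expected step is a 1.1-fold higher number from compound 1 to compound 3 (0.06 log units; within the scatter) and stays within the scatter. For compound 3 the estimated value is 2.3 ug/mL with an expected range from 1 ug/mL to 5 ug/mL in this assay.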

Compound 3, half-maximal inhibitory concentration: 2.09 ug/mL
Beside the measured number, compound 3's estimate is 1.1-fold (0.04 log units) above it, within the range that was stated.
By their numbers in this assay, from the lowest: compounds 1, 3 and 2 (each within the scatter of the next).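

In this assay, trifluoromethyl in place of hydrogen on an aromatic carbon, meta to a large group, gives a 1.0-fold higher number from compound 1 to compound 3 (0.02 log units; within the scatter) and so stays within the scatter. The earlier pair covered only methyl, so this place on the ring now also accommodates a group of 4 heavy atoms, including 3 fluorine, with no measurable change from compound 1. As far as these compounds go, whether an amine or a carboxylic acid at this same place would also stay within the scatter remains open. The series offers no separate measurement that bears on this flat result.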